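Replacing the 1-hydroxyethyl group of compound 2

This account rests on a few compounds, and the source may have more. Where it says the series, first, only, none or still open, it means among the compounds named here.

In an ADME assay on MT4 cells (Homo sapiens) for cytotoxicity, read by MTT assay, with a stated time of 96 h (a higher number here means that more compound is tolerated, a lower number that less compound is tolerated), compound 1 (`COc1ccc(-c2nc3cc(C(C)=O)ccc3[nH]2)c(OC)c1`) gives 50000 nM. Compound 2 (`COc1ccc(-c2nc3cc(C(C)O)ccc3[nH]2)c(OC)c1`) gives >= 100000 nM, which is a limit of the assay and not a number. Compound 2 therefore stands at the limit of >= 100000 nM in this assay, at which 1 of the 2 values shown sits. Among the measured compounds shown here, the only measured step on this aromatic carbon, 1-hydroxyethyl in place of acetyl, is an at least 2.0-fold higher number from compound 1 to compound 2 (0.30 log units; that floor lies within the scatter).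

Compound 3 (`COc1ccc(-c2nc3cc(/C(C)=N/O)ccc3[nH]2)c(OC)c1`) carries a new group at that same place, and the change is a group of 4 heavy atoms (2 carbon, 1 nitrogen, 1 oxygen; no ring) in place of a group of 3 heavy atoms (2 carbon, 1 oxygen; no ring), on an aromatic carbon. For the measured compounds named here, that single small step is the only guide, so no step beyond the scatter is expected in this assay. The estimated change is an at least 1.4-fold lower number from compound 2 to compound 3 (0.15 log units; that floor lies within the scatter). For compound 3 the expected value is 70000 nM, with an estimated range of 30000 nM to 100000 nM.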

Compound 3, half-maximal cytotoxic concentration: >= 100000 nM
Compound 3 ended at the assay's limit; the forecaster's own chance of this, stated with the estimate: 35%; middle value at least 1.4-fold (0.15 log units) from the limit.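

At this aromatic carbon, a second group in place of the acetyl of compound 1 now reads the same way in this assay, with an at least 2.0-fold higher number from compound 1 to compound 3 (0.30 log units; that floor lies within the scatter). Compound 2 and compound 3 both stand at a limit of the assay, not at a number, so the step between them cannot be read. The 1-hydroxyethyl group and the new group, with its nitrogen and its double bond outside the aromatic rings, therefore cannot be told apart here: the limit of >= 100000 nM in this assay, at which 2 of the 3 values shown sit.

Going by these compounds, whether an amine, a carboxylic acid or a longer chain on this aromatic carbon would also stay at that limit or give a measured number remains open. On these data alone, every readable step still lies within the scatter, so it also remains open whether the acetyl group truly differs from the other two groups.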